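The source may report more compounds than this note shows. Statements on the series, on what has been measured and on what is new or still open speak of the compounds shown alone.

Working notes on the series. Among the measured compounds shown here, the shared core carries a phenoxyacetic acid arm and a diphenyl oxazole joined through a short chain; the three measured members differ only at the chain carbon next to the oxazole. Compound 1 `O=C(O)COc1cccc(CCc2nc(-c3ccccc3)c(-c3ccccc3)o2)c1` has that carbon unsubstituted; in a functional assay for inhibition, with Homo sapiens as the target (on this read-out lower numbers stand for stronger inhibition and higher numbers for weaker inhibition), compound 1 gives 1200 nM. Compound 2 `CCOC(=O)C(Cc1cccc(OCC(=O)O)c1)c1nc(-c2ccccc2)c(-c2ccccc2)o1` adds an ethoxycarbonyl there, and in this assay compound 2 gives 120 nM. Compound 3 `C=CCC(Cc1cccc(OCC(=O)O)c1)(C(=O)OCC)c1nc(-c2ccccc2)c(-c2ccccc2)o1` carries both the ethoxycarbonyl and an allyl on that carbon; in this assay compound 3 gives 7680 nM, the highest number of the three.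

The two measured steps are as follows. Removing the ester, the change (hydrogen in place of ethoxycarbonyl on a saturated chain carbon bound to an aromatic carbon and a saturated chain carbon), gives a 10-fold higher number from compound 2 to compound 1 (1.00 log units; beyond the scatter). Adding the allyl to the ester-bearing carbon, the change (allyl in place of hydrogen on a saturated chain carbon bound to an aromatic carbon, a carbonyl carbon and a saturated chain carbon), gives a 64-fold higher number from compound 2 to compound 3 (1.81 log units; beyond the scatter); this is also how the core of compound 3 differs from the core of compound 2.

Compound 4 `C=CCC(Cc1cccc(OCC(=O)O)c1)c1nc(-c2ccccc2)c(-c2ccccc2)o1` is not yet measured. It arises from compound 3 by the change (hydrogen in place of ethoxycarbonyl on a saturated chain carbon bound to an aromatic carbon and two saturated chain carbons). For the measured compounds named here, this is the same kind of change as the one from compound 2 to compound 1, not the same: the carbon losing the ester is bound to an aromatic carbon and two saturated chain carbons in compound 3, against an aromatic carbon and one saturated chain carbon in compound 2. Because the like change gave a 10-fold higher number from compound 2 to compound 1 (1.00 log units; beyond the scatter), the step for compound 4 is expected to be a 2.0-fold higher number from compound 3 to compound 4 (0.29 log units; within the scatter), weakening but of uncertain size given that the allyl is already present. In this assay compound 4 is estimated at 15000 nM, within 3000 nM to 60000 nM.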

Compound 4, half-maximal inhibitory concentration: 570 nM
The estimate for compound 4 lay 26-fold (1.42 log units) above the measured number, outside the stated range (below it).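

In this assay, removing the ethoxycarbonyl from the carbon that also bears the allyl gives a 13-fold lower number from compound 3 to compound 4 (1.13 log units; beyond the scatter), so this change does not carry over from one core to the other and its direction reverses: the same change on two cores in this assay, a 10-fold higher number (1.00 log units; beyond the scatter) from compound 2 to compound 1 and a 13-fold lower number (1.13 log units; beyond the scatter) from compound 3 to compound 4, 130-fold (2.13 log units) apart, beyond the scatter of two such steps

The allyl does not carry over either, since allyl in place of hydrogen on the core without the ester gives a 2.1-fold lower number from compound 1 to compound 4 (0.32 log units; beyond the scatter), whereas on the ester-bearing core the number rises: the same change on two cores in this assay, a 64-fold higher number (1.81 log units; beyond the scatter) from compound 2 to compound 3 and a 2.1-fold lower number (0.32 log units; beyond the scatter) from compound 1 to compound 4, 130-fold (2.13 log units) apart, beyond the scatter of two such steps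

Together with a 4.8-fold higher number from compound 2 to compound 4 (0.68 log units; beyond the scatter), the direct exchange of ethoxycarbonyl for allyl, these steps show that in these four compounds the outcome of either change depends on what else sits on that carbon; they do not show why, and each comparison rests on a single pair of cores, so no general rule for the series follows.

From the compounds shown here alone, it remains open whether a saturated propyl chain or a longer chain in place of the allyl would give the same reversal. Going by these compounds, it is equally open whether a carboxylic acid or an amide in place of the ethoxycarbonyl would behave as the ester does, alone or together with the allyl.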